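The source may hold more compounds than are shown below. What is called first, only, known or untested is meant among the compounds shown, and "the series" means these compounds.

Measured compounds in a functional assay on MCF7 cells (Homo sapiens) for cytotoxicity, read by MTT assay, with a stated time of 72 h; a higher number here means that more compound is tolerated, a lower number that less compound is tolerated:
compound 1, `C[Se]/C(=N\C(=O)c1cc2ccccc2s1)NC(=O)c1cc2ccccc2s1`: compound 1 gives 80600 nM.
compound 2, `CS/C(=N\C(=O)c1csc([N+](=O)[O-])c1)NC(=O)c1csc([N+](=O)[O-])c1`: compound 2 gives only a limit, > 100000 nM.
compound 3, `C[Se]/C(=N\C(=O)c1ccco1)NC(=O)c1ccco1`: compound 3 gives only a limit, > 100000 nM.

Compound 3 thus stands at the limit of this assay, with no number behind it. The same holds for compound 2, which shares that limit (the limit of > 100000 nM in this assay, at which 2 of the 3 values shown sit). Among the compounds with values here, compound 1 is the only member of the series with an actual number in this assay, and that number lies close to the limit shared by the other two.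

Compound 4, `CS/C(=N\C(=O)c1ccco1)NC(=O)c1ccco1`, differs from compound 3 by a group of 2 heavy atoms (1 carbon, 1 sulfur; no ring) in place of a group of 2 heavy atoms (1 carbon, 1 selenium; no ring), on a carbon with a double bond to nitrogen. Compound 2 already carries the methylsulfanyl group on the same carbon with a double bond to nitrogen and sits at the limit. Within the data shown here, no step between two measured compounds is available to calibrate this exchange, so the step from compound 3 to compound 4 is expected to stay within the scatter, with no direction beyond it; most likely compound 4 again returns only a limit in this assay. The expected step is a step that the limit leaves unreadable from compound 3 to compound 4. For compound 4 the estimate in this assay is 150000 nM, with a range from 60000 nM to 400000 nM.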

Compound 4, concentration lethal to 50% of the cells: > 100000 nM
Compound 4: only a limit was reported; the forecaster's own chance of this, stated with the estimate: 75%; the middle value lies beyond the limit too.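

Compound 3 and compound 4 both return only a limit in this assay, so the exchange of the selenium-bearing group for methylsulfanyl gives no readable step: the limit of > 100000 nM in this assay, at which 3 of the 4 values shown sit.

The compounds shown leave open what this exchange, on a carbon with a double bond to nitrogen, does in a pair where both compounds give a number rather than a limit.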